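Four compounds with one amine-bearing chain

The source may report more compounds than this note shows. Statements on the series, on what has been measured and on what is new or still open speak of the compounds shown alone.

Compound 1 `CCN(CC)CCCCOc1ccc(/C=C/C(=O)Nc2ccccc2)cc1OC` is the reference. In a physicochemical assay for lipophilicity, using the shake flask method, measured as octanol-water partition, at pH 7.4 (on this read-out lower numbers stand for lower lipophilicity and higher numbers for higher lipophilicity), compound 1 gives 1.59. Compound 2 `COc1cc(/C=C/C(=O)Nc2ccccc2)ccc1OCCCCCCN(C)C` differs from it by 2-(dimethylamino)ethyl in place of diethylamino on a saturated chain carbon, four bonds along the chain from an oxygen on an aromatic ring, and the step is a number 0.10 log units higher from compound 1 to compound 2 (within the scatter). Compound 3 `CCN(CC)CCCCCCCCOc1ccc(/C=C/C(=O)Nc2ccccc2)cc1OC` differs from compound 1 by 4-(diethylamino)butyl in place of diethylamino on a saturated chain carbon, four bonds along the chain from an oxygen on an aromatic ring; in this assay compound 3 gives 1.75, while compound 2 gives 1.69. The three values stay close, as a number 0.16 log units higher from compound 1 to compound 3 (within the scatter) and a number 0.06 log units higher from compound 2 to compound 3 (within the scatter) show. Compound 4 `COc1cc(/C=C/C(=O)Nc2ccccc2)ccc1OCCCCCCCCCCN(C)C` has not yet been measured; it differs from compound 3 by 2-(dimethylamino)ethyl in place of diethylamino on a saturated chain carbon, eight bonds along the chain from an oxygen on an aromatic ring. This is the same kind of change as that from compound 1 to compound 2, though the place is not the same: four bonds along the chain from an oxygen on an aromatic ring there, eight bonds along the chain from an oxygen on an aromatic ring here. Resting on that earlier step, which was a number 0.10 log units higher from compound 1 to compound 2 (within the scatter), the step from compound 3 to compound 4 is expected to be a number 0.10 log units higher from compound 3 to compound 4 (within the scatter). Compound 4 is therefore estimated at 1.85, between 1.55 and 2.15.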

Compound 4, partition coefficient: 1.8
Beside the measured number, compound 4's estimate is 0.05 log units above it; the measured number falls inside the stated range.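

In this assay the change from diethylamino to 2-(dimethylamino)ethyl on the longer chain gives a number 0.05 log units higher from compound 3 to compound 4 (within the scatter) and so lies within the scatter, as does the same change at four bonds along the chain, a number 0.10 log units higher from compound 1 to compound 2 (within the scatter) on the shorter one. The other new steps, a number 0.11 log units higher from compound 2 to compound 4 (within the scatter) and a number 0.21 log units higher from compound 1 to compound 4 (within the scatter) within the scatter as well, leave all four compounds indistinguishable on this read-out, but all four share one core, so nothing shows how the change would carry to a different core. Nothing at hand bears on why these values stay together.

The compounds shown leave open whether a piperidine at the chain end would stay this close. The same holds for a carboxylic acid in place of the amine.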